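A few compounds are considered here, and "the series" means these few. Any claim that something is new, unique, unknown or untested is made for them only; others in the source may bear on it.

Three measured compounds share a biaryl amide bearing a carboxylic acid. Compound 1 `Cc1cc(C(=O)O)cc(C)c1NC(=O)c1cc(-c2cccc(CO)c2)ccc1F` and compound 2 `Cc1ccc(C(=O)O)c(C)c1NC(=O)c1cc(-c2cccc(CO)c2)ccc1F` have the same atoms joined differently; the difference between the two cores is not broken down here. Compound 3 `Cc1ccc(-c2cccc(CO)c2)cc1C(=O)Nc1c(C)ccc(C(=O)O)c1C` arises from compound 2 by methyl in place of fluoro on an aromatic carbon.

In a physicochemical assay for solubility, read by HPLC, with a stated time of 20 h, at pH 6 (on this read-out lower numbers stand for lower solubility and higher numbers for higher solubility), compound 1 gives 774 ug/mL, compound 2 gives 709 ug/mL, and compound 3 gives 783 ug/mL. The step of a 1.1-fold higher number from compound 2 to compound 3 (0.04 log units; within the scatter) shows that the exchange made no real difference on this read-out, and all three values lie close together.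

Compound 4 `Cc1ccc(-c2cccc(CO)c2)cc1C(=O)Nc1c(C)cc(C(=O)O)cc1C` has not yet been measured. It arises from compound 1 by methyl in place of fluoro on an aromatic carbon, the same change already seen once between compound 2 and compound 3, at the same place. Because that earlier step was a 1.1-fold higher number from compound 2 to compound 3 (0.04 log units; within the scatter), he expects the step of a 1.0-fold higher number from compound 1 to compound 4 (0.01 log units; within the scatter) in this assay to be of similar, small size. Since compound 1 gives 774 ug/mL, compound 4 is estimated at 800 ug/mL, within a range from 500 ug/mL to 1300 ug/mL.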

Compound 4, solubility: 31 ug/mL
Compound 4: the middle estimate sits 26-fold (1.41 log units) above what was measured, and the stated range ends above it.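

In this assay the same exchange, methyl in place of fluoro on an aromatic carbon, gave a 1.1-fold higher number from compound 2 to compound 3 (0.04 log units; within the scatter) but a 25-fold lower number from compound 1 to compound 4 (1.40 log units; beyond the scatter) on the other core. The change therefore did not carry from the core of compound 2 to the core of compound 1, and the step seen on one core was no safe guide to the step on the other. For the compounds shown here, with only one such pair on each core, the result does not show how this exchange would behave on any further core, and nothing given here accounts for the gap between the two steps.

The compounds shown leave open whether chloro or a nitrile in place of the fluoro would give a small step or a large one on the core of compound 1. They also leave open whether the large step would persist with an amine in place of the carboxylic acid.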